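The source may hold more compounds than are shown below. What is called first, only, known or untested is meant among the compounds shown, and "the series" means these compounds.

Of the compounds shown here, two that share a core have been measured in an in vitro ADME assay on microsomes from liver (Homo sapiens) for pharmacokinetics, read by LC-MS, with a stated time of 10 min, tested at 1 uM; a higher number here means faster removal of the compound, a lower number slower removal: compound 1 `CN1C[C@H](C(=O)Nc2ccccc2F)[C@@H](c2ccc(/C=C/C(=O)Nc3ccccc3N)cc2)C1` gives 10 mL/min/kg, and compound 2 `CCN1C[C@H](C(=O)Nc2ccc(Cl)cc2)[C@@H](c2ccc(/C=C/C(=O)Nc3ccccc3N)cc2)C1` gives 12 mL/min/kg. These two numbers lie within the usual scatter of repeated measurements, so compound 2 stands level with compound 1 on the data so far.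

Compound 3 `CC(C)(CO)N1C[C@H](C(=O)Nc2ccc(Cl)cc2)[C@@H](c2ccc(/C=C/C(=O)Nc3ccccc3N)cc2)C1` keeps all of compound 2 except one group. It carries 1-(hydroxymethyl)-1-methylethyl in place of ethyl on an amine nitrogen in a ring. Among the compounds with values here, the two measured compounds differ from each other in more than one place, so no measured pair shows what a single change at this nitrogen does. The expectation is therefore a loose one, anchored on compound 2 at 12 mL/min/kg and given a wide range.

The expected change is a 1.5-fold lower number from compound 2 to compound 3 (0.18 log units; within the scatter), a small move toward slower removal that may well stay within the scatter. For compound 3 the estimated clearance in this assay is 8 mL/min/kg, with an expected range from 4 mL/min/kg to 16 mL/min/kg.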

Compound 3, clearance: 12 mL/min/kg
For compound 3 the middle estimate is 1.5-fold (0.18 log units) below the measured one; the range from low to high includes it.
By their numbers in this assay, from the lowest: compounds 1, 2 and 3 (each within the scatter of the next).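

Within the data shown here, the step at the amine nitrogen in the ring is the first single-place comparison, and in this assay exchanging ethyl for 1-(hydroxymethyl)-1-methylethyl gives no change at the digits printed from compound 2 to compound 3 (within the scatter) at this position. The entering group has more heavy atoms than ethyl and brings a hydrogen-bond donor and a hydrogen-bond acceptor that ethyl lacks, yet neither addition shows up as a difference in clearance for this pair. Nothing available explains why the reading stays level, so this pair records the outcome without giving its cause.

This single step changes the branching and adds the hydroxyl at the same time, so it cannot show what either would do alone, and a smaller group such as 2-hydroxyethyl would be needed to begin separating them. It also leaves open whether the nitrogen would stay as undemanding with a different kind of group, such as a chain ending in a carboxylic acid or in an amine, or whether the same exchange would read alike with the 2-fluorophenyl amide of compound 1.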